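Dropping the Chloro from the 3-Chlorobenzyl Group

The source may report more compounds than this note shows. Statements on the series, on what has been measured and on what is new or still open speak of the compounds shown alone.

Compound 1 `CC1CCN(Cc2ccc3nc(NC(=O)N/N=C/c4cn(Cc5cccc(Cl)c5)c5ccccc45)sc3c2)CC1`: 2810 nM
Compound 2 `CCN(CC)Cc1ccc2nc(NC(=O)N/N=C/c3cn(Cc4cccc(Cl)c4)c4ccccc34)sc2c1`: 2410 nM
Compound 3 `CN(C)Cc1ccc2nc(NC(=O)N/N=C/c3cn(Cc4cccc(Cl)c4)c4ccccc34)sc2c1`: 1240 nM

All three values come from a functional assay on A549 cells (Homo sapiens) for cytotoxicity, read by MTT assay, with a stated time of 72 h; on this read-out higher numbers stand for weaker inhibition and lower numbers for stronger inhibition. The middle number of the three belongs to compound 2, and its two steps, a 1.2-fold lower number from compound 1 to compound 2 (0.07 log units; within the scatter) and a 1.9-fold lower number from compound 2 to compound 3 (0.29 log units; within the scatter), stay within the scatter. Compound 4 `CCN(CC)Cc1ccc2nc(NC(=O)N/N=C/c3cn(Cc4ccccc4)c4ccccc34)sc2c1` differs from compound 2 as follows: hydrogen in place of chloro on an aromatic carbon. Among the measured compounds shown here, no measured step touches that place. All three steps exchange groups on a saturated chain carbon, and the largest, a 2.3-fold lower number from compound 1 to compound 3 (0.36 log units; beyond the scatter), is only modest. They therefore give no direction and only a rough scale for this assay. The expected change is small, a 1.2-fold higher number from compound 2 to compound 4 (0.08 log units; within the scatter), and not beyond the scatter. For compound 4 the estimated value is 2900 nM, with an expected range of 1200 nM to 7000 nM.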

Compound 4, half-maximal inhibitory concentration: 3330 nM
The estimate for compound 4 lay 1.1-fold (0.06 log units) below the measured number; low and high end bracket the measured number.
By their numbers in this assay, from the lowest: compounds 3, 2, 1 and 4 (each within the scatter of the next, the first and the last beyond it).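

In this assay, among the compounds shown here, the first change on the 3-chlorobenzyl group, to benzyl, gives a 1.4-fold higher number from compound 2 to compound 4 (0.14 log units; within the scatter) and so stays within the scatter. In this pair, with diethylamino held fixed, the chloro on the aromatic carbon is thus not needed to keep the number at this level, though a single pair carries that reading. No measurement at hand bears on why this is so. The compounds shown leave open whether fluoro, methoxy or trifluoromethyl at this place would move the number beyond the scatter. They also leave open whether the same exchange holds with the dimethylamino group of compound 3.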